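The compounds below may be only part of what the source reports. "The series", "measured", "known", "first", "only" and "open" are said of these compounds alone.

In a functional assay on HepG2 cells (Homo sapiens) for inhibition, read by MTT assay (on this read-out higher numbers stand for weaker inhibition and lower numbers for stronger inhibition), compound 1 (`COc1cc2ncnc(Nc3ccc(NC(=O)c4ccccc4C)cc3)c2cc1OC`) gives 15000 nM and compound 3 (`COc1cc2ncnc(Nc3ccc(NC(=O)c4ccc(F)cc4)cc3)c2cc1OC`) gives 15000 nM, so the two stand level. Compound 2 (`COc1cc2ncnc(Nc3ccc(NC(=O)c4ccccc4OC)cc3)c2cc1OC`) gives > 100000 nM, which is a limit of the assay and not a number.

Compound 4 (`COc1cc2ncnc(Nc3ccc(NC(=O)c4ccccc4Cl)cc3)c2cc1OC`) has not yet been measured. It has 2-chlorophenyl in place of 4-fluorophenyl on a carbonyl carbon.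

For the measured compounds named here, two measured steps bear on this change. One, 4-fluorophenyl in place of 2-methylphenyl on a carbonyl carbon, gave no change at the digits printed from compound 1 to compound 3 (within the scatter). The other, methoxy in place of methyl on an aromatic carbon, gave an at least 6.6-fold higher number from compound 1 to compound 2 (0.82 log units; beyond the scatter). The first of these suggests little movement, while the second leaves room for a higher number, so the range is drawn wider on the upper side.

The expected result is a 1.3-fold higher number from compound 3 to compound 4 (0.12 log units; within the scatter), with no shift beyond the scatter anticipated. Compound 4 is estimated at 20000 nM, with an expected range of 8000 nM to 70000 nM.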

Compound 4, half-maximal inhibitory concentration: 26000 nM
For compound 4 the middle estimate is 1.3-fold (0.11 log units) below the measured one, within the range that was stated.
By their numbers in this assay, from the lowest: compounds 1, 3 and 4 (each within the scatter of the next). At a limit, above all of these: compound 2.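

In this assay, chloro in place of methyl on an aromatic carbon gives a 1.7-fold higher number from compound 1 to compound 4 (0.24 log units; within the scatter), and 2-chlorophenyl in place of 4-fluorophenyl on a carbonyl carbon gives a 1.7-fold higher number from compound 3 to compound 4 (0.24 log units; within the scatter), so compounds 1, 3 and 4 stand level within the scatter. Chloro in place of methoxy on an aromatic carbon gives an at least 3.8-fold lower number from compound 2 to compound 4 (0.58 log units; beyond the scatter), so of the three groups now seen on that aromatic carbon, only the methoxy of compound 2 stands apart from the others. The value of compound 2 is a limit of the assay and not a number: the limit of > 100000 nM in this assay, at which 1 of the 4 values shown sits.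

The compounds shown leave open whether an amine or a carboxylic acid on that aromatic carbon would stay level with methyl and chloro or part from them as methoxy does. They also leave open whether a longer chain, such as ethoxy, would behave as methoxy does, and they give no reason for the gap.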